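A few compounds are considered here, and "the series" means these few. Any claim that something is new, unique, unknown or untested is made for them only; others in the source may bear on it.

In a functional assay on NCI-H1650 cells (Homo sapiens) for inhibition, read by MTT assay, with a stated time of 48 h (a higher number here means a weaker inhibitor of growth, a lower number a stronger inhibitor of growth), compound 1 `O=S(=O)(NC1CCC2(OC1)c1ccccc1CCc1ccccc12)c1ccc(C(F)(F)F)cc1` gives 15000 nM and compound 2 `O=S(=O)(NC1CCC2(OC1)c1ccccc1CCc1ccccc12)c1ccc(Cl)cc1` gives 25000 nM on the same core, so compound 2 stands within the usual scatter of compound 1 and cannot be told apart from it. Compound 3 `O=S(=O)(NC1CCC2(OC1)c1ccccc1CCc1ccccc12)c1ccc(F)cc1` is still unmeasured and differs from compound 2 by a single swap (fluoro in place of chloro on an aromatic carbon), fluoro in place of chloro on an aromatic carbon, which turns 4-chlorophenyl into 4-fluorophenyl. For the measured compounds named here, one measured step bears on this, chloro in place of trifluoromethyl on an aromatic carbon, and it came to a 1.7-fold higher number from compound 1 to compound 2 (0.22 log units; within the scatter) without leaving the scatter. On that single example, no step beyond the scatter is expected in this assay and no direction is favoured. The estimate is no change at the digits printed from compound 2 to compound 3 (within the scatter) as the expected step. Compound 3 is therefore expected at 25000 nM with an estimated range from 12000 nM to 50000 nM as its likely span.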

Compound 3, concentration for 50% growth inhibition: 20000 nM
Estimate against measurement, compound 3: 1.3-fold (0.10 log units) above; low and high end bracket the measured number.
By their numbers in this assay, from the lowest: compounds 1, 3 and 2 (each within the scatter of the next).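

In this assay, putting fluoro in place of chloro gives a 1.3-fold lower number from compound 2 to compound 3 (0.10 log units; within the scatter), and putting fluoro in place of trifluoromethyl gives a 1.3-fold higher number from compound 1 to compound 3 (0.12 log units; within the scatter), with both steps within the scatter. For the compounds shown here, the earlier compounds offered only one comparison at this aromatic carbon, whereas all three groups can now be compared there, and no two of them can be told apart, so these swaps do not separate the compounds in this growth read-out. Nothing measured here explains why the three compounds cannot be separated.

On these data alone, whether this insensitivity extends to very different groups remains open, such as an amine, a carboxylic acid or a methoxy group on the same carbon. The compounds shown also leave open whether plain hydrogen there, or a change elsewhere on the shared core, would produce a step beyond the scatter.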